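From an Indene to an Indane on the Chain

The compounds below may be only part of what the source reports. "The series", "measured", "known", "first", "only" and "open" are said of these compounds alone.

Of the compounds shown here, three sharing one core have been tested in an assay for activation of Adrenergic receptor alpha-1 (Rattus norvegicus); a higher number here means that more compound is needed for the effect, a lower number that less compound is needed. Compound 1 `c1ccc2c(c1)CC2CCCN1CCN(c2cccc3c2OCCO3)CC1` gives 0.45 mg/kg. Compound 2 `C1=C(CCN2CCN(c3cccc4c3OCCO4)CC2)Cc2ccccc21` gives 0.17 mg/kg. Compound 3 `c1ccc2c(c1)CCCC2CCN1CCN(c2cccc3c2OCCO3)CC1` gives 5 mg/kg. Compound 2 stands at the lowest number of the three; compound 1 lies nearest to it, and compound 3 lies furthest, beyond the scatter in both cases.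

Among the compounds with values here, the only measured step between neighbours is a 2.6-fold lower number from compound 1 to compound 2 (0.42 log units; beyond the scatter), a modest lowering of the dose. Compound 4 `c1ccc2c(c1)CCC2CCN1CCN(c2cccc3c2OCCO3)CC1` is not yet measured in this assay. It differs from compound 2 in one place: a group of 9 heavy atoms (9 carbon; one five-membered non-aromatic ring of carbon only, one six-membered aromatic ring of carbon only) in place of a group of 9 heavy atoms (9 carbon; one five-membered non-aromatic ring of carbon only, one six-membered aromatic ring of carbon only), on a saturated chain carbon, two bonds along the chain from an amine nitrogen in a ring. Within the data shown here, no measured pair shows this kind of change, the loss of a double bond outside aromatic rings while the ring size stays the same, so the measured step gives only indirect guidance. The values of compound 1 and compound 3 show that the size of the non-aromatic ring matters strongly, and compound 4 keeps the five-membered ring of compound 2. The step of a 1.8-fold higher number from compound 2 to compound 4 (0.25 log units; within the scatter) is therefore expected to stay small, within or close to the scatter. Compound 4 is expected to give about 0.3 mg/kg, in a range from 0.1 mg/kg to 1 mg/kg.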

Compound 4, dose for half-maximal effect: 4.01 mg/kg
Estimate against measurement, compound 4: 13-fold (1.13 log units) below; the whole stated range lies below it.
By their numbers in this assay, from the lowest: compound 2; then compound 1; then compounds 4 and 3 (each within the scatter of the next).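

In this assay, keeping the five-membered ring does not keep the number low: putting 2,3-dihydro-1H-inden-1-yl in place of the group with a double bond outside aromatic rings gives a 24-fold higher number from compound 2 to compound 4 (1.37 log units; beyond the scatter) on the same saturated chain carbon. Ring size alone therefore does not account for the order of these compounds, since the step of an 8.9-fold higher number from compound 1 to compound 4 (0.95 log units; beyond the scatter) leaves the five-membered ring of compound 4 on the higher side of the four-membered ring of compound 1, while compound 2, also with a five-membered ring, stands lowest of all, and compound 4 now sits within the scatter of compound 3, which has a six-membered ring. Nothing measured here gives a reason for either step.

The compounds shown leave open whether the large step belongs to the double bond itself or to the way the two groups are joined to the chain, as the one change carries both. On these data alone, it also remains open how a hydroxyl group or a methyl group on the saturated ring of compound 4 would move the number in this assay, or whether a longer chain would restore the low dose.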